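The source may report more compounds than this note shows. Statements on the series, on what has been measured and on what is new or still open speak of the compounds shown alone.

Measured compounds:
compound 1 `COc1ccc(-c2csc(N)c2C(=O)Oc2ccccc2)cc1OC`: 48%
compound 2 `COc1ccc(-c2csc(N)c2C(=O)OCc2ccc(F)cc2)cc1OC`: 2%
compound 3 `COc1ccc(-c2csc(N)c2C(=O)NCc2ccncc2)cc1OC`: 3%

All three share one core and differ only at the carbonyl group. In an assay on isolated protein for inhibition of protein kinase C zeta type (Homo sapiens), with stated times of 1 h and 2.5 min, tested at 30 uM (a higher number here means more inhibition at the concentration tested (going by the name of the read-out), a lower number less inhibition), compound 3 sits second of the three numbers: its nearest neighbour is compound 2, which lies close to it, as the step of a number 1 percentage points higher from compound 2 to compound 3 (within the scatter) shows; compound 1 stands far away, the gap being a number 45 percentage points lower from compound 1 to compound 3 (beyond the scatter) in the other direction. The further step a number 46 percentage points lower from compound 1 to compound 2 (beyond the scatter) shows the same drop on moving away from compound 1.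

Compound 4 `COc1ccc(-c2csc(N)c2C(=O)O)cc1OC` is the next member. It differs from compound 3 by hydroxy in place of ((pyridin-4-yl)methyl)amino on a carbonyl carbon. Among the compounds with values here, no measured step replaces the whole group on the carbonyl carbon by hydroxy, so the two steps that bear on it are those leading to compound 3, both large and both downward, and the step between compound 2 and compound 3, which is within the scatter. Compound 4 is therefore expected to stay near compound 3, with an expected step of a number 2 percentage points higher from compound 3 to compound 4 (within the scatter) in this assay. The estimate for compound 4 is 5%, with a range from -5% to 20%.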

Compound 4, a percentage reported as inhibition, at one concentration (the size of the read-out at that concentration, not a potency): 65%
Compound 4: the middle estimate sits 60 percentage points below what was measured, outside the stated range (above it).
By their numbers in this assay, from the lowest: compounds 2 and 3 (each within the scatter of the next); then compound 1; then compound 4.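

In this assay the step of a number 62 percentage points higher from compound 3 to compound 4 (beyond the scatter) shows that hydroxy on the carbonyl carbon gives a high number where ((pyridin-4-yl)methyl)amino gave a low one. The step of a number 63 percentage points higher from compound 2 to compound 4 (beyond the scatter) shows the same on the oxygen, with hydrogen in place of 4-fluorobenzyl. Phenyl had been the only group on that oxygen with a clear number, yet the modest step of a number 17 percentage points higher from compound 1 to compound 4 (beyond the scatter) shows that hydrogen goes beyond it, so among these compounds the substituent on the oxygen is not required for inhibition at the concentration tested.

Going by these compounds, whether a methyl ester or an unsubstituted amide at this carbonyl carbon would give a high or a low number stays open. Nothing shown here explains why these steps are so large.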